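The compounds below may be only part of what the source reports. "The series", "measured", "known", "first", "only" and "open" are said of these compounds alone.

Compound 1 `COc1ccc(/C=C/C(=O)/C=C/c2ccc(OCc3cn(CCCCCOc4cc(=O)oc5ccccc45)nn3)c(OC)c2)cc1OC`: 45%
Compound 2 `COc1ccc(/C=C/C(=O)/C=C/c2ccc(OCc3cn(CCCCCOc4cc(=O)oc5ccccc45)nn3)c(OC)c2)cc1`: 35%

Both compounds were tested in a functional assay on HCT-116 cells (Homo sapiens) for inhibition, read by sulforhodamine B assay, with a stated time of 48 h, tested at 50 uM; a lower number here means less inhibition of growth, a higher number more inhibition of growth at the concentration tested. Going by the values given here, there compound 2, at 35%, stands within the scatter of compound 1, the only other compound measured: a number 10 percentage points lower from compound 1 to compound 2 (within the scatter).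

Compound 3 `COc1cc(/C=C/C(=O)/C=C/c2cc(OC)c(OC)c(OC)c2)ccc1OCc1cn(CCCCCOc2cc(=O)oc3ccccc23)nn1` carries 3,4,5-trimethoxyphenyl in place of 4-methoxyphenyl on a double-bonded chain carbon bound to a double-bonded chain carbon.

Among the compounds with values here, only one measured step bears on this change. It is the exchange of hydrogen for methoxy on an aromatic carbon that separates compound 1 from compound 2, and it stayed within the scatter: a number 10 percentage points lower from compound 1 to compound 2 (within the scatter). That is thin evidence, and the new group differs by more than that single exchange. A small rise in this assay is expected, but nothing beyond the scatter. The estimated change is a number 7 percentage points higher from compound 2 to compound 3 (within the scatter). Compound 3 is expected to give 42%, with an estimated range of 25% to 60%.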

Compound 3, percent growth inhibition at one concentration: 53%
Estimate against measurement, compound 3: 11 percentage points below; low and high end bracket the measured number.
By their numbers in this assay, from the lowest: compounds 2, 1 and 3 (each within the scatter of the next, the first and the last beyond it).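

In this assay, going by these compounds alone, the full exchange of 4-methoxyphenyl for 3,4,5-trimethoxyphenyl gives the first step beyond the scatter in this small set, a number 18 percentage points higher from compound 2 to compound 3 (beyond the scatter), so this position on the double-bonded chain can register a modest difference. The single added methoxy gives only a number 8 percentage points higher from compound 1 to compound 3 (within the scatter), which lies within the scatter, so the difference becomes readable only across the whole exchange and cannot be assigned to any one methoxy group. No available evidence bears on what lies behind this rise.

The compounds shown leave open whether a hydroxy group, an amine or a carboxylic acid in place of these methoxy groups on the ring would keep, raise or lower the growth inhibition. They also leave open how a longer chain before the triazole-linked end of the molecule would alter the result.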